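Working notes: amide nitrogen variation on the shared core

A few compounds are considered here, and "the series" means these few. Any claim that something is new, unique, unknown or untested is made for them only; others in the source may bear on it.

Measured so far:
compound 1 `Cc1cc(C(=O)O)nn1C(C)c1cc(Cl)ccc1OCc1ccccc1` — 10 nM
compound 2 `Cc1cc(C(=O)NC(C)C)nn1Cc1cc(Cl)ccc1OCc1ccccc1` — 126 nM

In an assay on CHO-K1 cells for displacement of a labelled ligand from prostaglandin E2 receptor EP1 subtype (Homo sapiens) (on this read-out lower numbers stand for stronger inhibition and higher numbers for weaker inhibition), compound 1 gives 10 nM, while compound 2 gives 126 nM. Compound 2 therefore stands at the higher of the two numbers recorded, the gap to compound 1 lying beyond the usual scatter. The two compounds differ in more than one place, so no single step can be read between them; the two values are all that can be said.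

Compound 3 `Cc1cc(C(=O)Nc2ccccn2)nn1Cc1cc(Cl)ccc1OCc1ccccc1` is the next member to be measured. It differs from compound 2 in one place: pyridin-2-yl in place of isopropyl on an amide-type nitrogen. Within the data shown here, no measured pair in the set shows this kind of change, so there is no step to lean on; the expectation rests only on compound 2 giving 126 nM and on the nature of the exchange.

For compound 3 a modest move toward a lower number is expected, the step of a 1.8-fold lower number from compound 2 to compound 3 (0.26 log units; within the scatter) being of a size that may or may not clear the scatter. The estimate for compound 3 in this assay is 70 nM, within 15 nM to 350 nM.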

Compound 3, half-maximal inhibitory concentration: 126 nM
For compound 3 the middle estimate is 1.8-fold (0.26 log units) below the measured one; measured number inside the range.
By their numbers in this assay, from the lowest: compound 1; then compounds 2 and 3 (each within the scatter of the next).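

Working notes, continued: in this assay, replacing isopropyl with pyridin-2-yl on the amide-type nitrogen gives no change at the digits printed from compound 2 to compound 3 (within the scatter), the first step in the series that can be read at a single place. At this position, therefore, an open isopropyl group with 3 heavy atoms and an aromatic pyridin-2-yl ring with 6 heavy atoms and 1 hydrogen-bond acceptor give readings that cannot be told apart, although this single pair sets no rule for other groups on that nitrogen. No measurement in hand speaks to the reason for this outcome.

From the compounds shown here alone, it remains open whether the same holds for other groups on the amide-type nitrogen, such as phenyl, pyridin-4-yl, a longer alkyl chain or a primary amine-derived amide carrying only hydrogen there. Also open, going by these compounds, is what separates these amides from compound 1 at 10 nM, which differs from them in more than one place, so that its number cannot be tied to any single change.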